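A few compounds are considered here, and "the series" means these few. Any claim that something is new, unique, unknown or untested is made for them only; others in the source may bear on it.

Working notes on the series. Compound 3 `NC(=O)CCC1CCN(c2nc(-c3cc(F)c(Cl)cc3F)nc3c2CS(=O)(=O)C3)CC1` sits second highest of the three numbers in a functional assay on the whole organism (blood, strain ICR) with Mus musculus as the target, in the glucose tolerance test, with a stated time of 30 min; on this read-out lower numbers stand for an effect already at smaller amounts and higher numbers for an effect only at larger amounts of compound: compound 3 gives 0.3 mg/kg, while compound 2 `NC(=O)CC1CCN(c2nc(-c3cc(F)c(Cl)cc3F)nc3c2CS(=O)(=O)C3)CC1` gives 0.1 mg/kg and compound 1 `CN(C)C(=O)C1CCN(c2nc(-c3cc(F)c(Cl)cc3F)nc3c2CS(=O)(=O)C3)CC1` gives 1 mg/kg. The measured steps are a 3.0-fold higher number from compound 2 to compound 3 (0.48 log units; beyond the scatter) and a 3.3-fold lower number from compound 1 to compound 3 (0.52 log units; beyond the scatter), with a 10-fold lower number from compound 1 to compound 2 (1.00 log units; beyond the scatter) joining the two ends.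

The next compound is compound 4 `CNC(=O)C1CCN(c2nc(-c3cc(F)c(Cl)cc3F)nc3c2CS(=O)(=O)C3)CC1`, which differs from compound 3 in one place: methylcarbamoyl in place of 2-carbamoylethyl on a saturated ring carbon. Compound 4 thus carries its amide directly on the saturated ring carbon, as compound 1 does, rather than on a chain of the kind seen in compound 2 and compound 3. The step that bears most is a 3.3-fold lower number from compound 1 to compound 3 (0.52 log units; beyond the scatter), since compound 4 returns the amide to the ring carbon while keeping one hydrogen-bond donor that compound 1 lacks. A shift back toward the number of compound 1 is expected, but only part of the way, so that the step from compound 3 is estimated as a 2.0-fold higher number from compound 3 to compound 4 (0.30 log units; within the scatter), close to the scatter. Compound 4 is therefore estimated at 0.6 mg/kg in this assay, with a range from 0.15 mg/kg to 2.5 mg/kg.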

Compound 4, minimum effective dose: 3 mg/kg
The estimate for compound 4 lay 5.0-fold (0.70 log units) below the measured number; the measured number lies above the stated range.
By their numbers in this assay, from the lowest: compound 2; then compound 3; then compound 1; then compound 4.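

On the saturated ring carbon, the methylcarbamoyl group of compound 4 gives a 10-fold higher number from compound 3 to compound 4 (1.00 log units; beyond the scatter) and a 30-fold higher number from compound 2 to compound 4 (1.48 log units; beyond the scatter) in this assay, so among these compounds both chain-borne primary amides, 2-carbamoylethyl and carbamoylmethyl, act at smaller amounts than this amide placed directly on the ring carbon. Among the amides directly on that carbon, hydrogen in place of methyl on the amide-type nitrogen gives a 3.0-fold higher number from compound 1 to compound 4 (0.48 log units; beyond the scatter), so the dimethylcarbamoyl group of compound 1 stands lower than the methylcarbamoyl group. Nothing measured here accounts for these steps.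

As far as these compounds go, it remains open whether a plain carbamoyl group directly on the ring carbon continues this trend from dimethylcarbamoyl to methylcarbamoyl. Also open, from the compounds shown here alone, is whether a carboxylic acid on the carbamoylmethyl chain, or a chain longer than 2-carbamoylethyl, would hold the low number seen for compound 2.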